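Benzyl swap on the diamino core in this cell assay

The compounds below may be only part of what the source reports. "The series", "measured", "known", "first", "only" and "open" are said of these compounds alone.

Compound 1 `Nc1cc(N)c2nc(-c3ccccc3)c(NCc3ccc(Cl)c(Cl)c3)nc2c1` is one of three members carrying the shared core. In a functional assay on HCT-116 cells (Homo sapiens) for inhibition, read by sulforhodamine B assay, with a stated time of 48 h (a lower number here means that less compound is tolerated, a higher number that more compound is tolerated), compound 1 gives 50100 nM, the higher of the two numbers in hand. Compound 3 `COc1cc(CNc2nc3cc(N)cc(N)c3nc2-c2ccccc2)cc(OC)c1OC` gives 37200 nM in this assay, within the scatter of compound 1. Compound 2 `CCOC(=O)[C@H](CCC(=O)O)NC(=O)c1ccc(Sc2nc3cc(N)cc(N)c3nc2-c2ccccc2)cc1` reaches only a limit of this assay at < 100000 nM. (the limit of < 100000 nM in this assay, at which 1 of the 3 values shown sits). The step to compound 4 `Nc1cc(N)c2nc(-c3ccccc3)c(NCc3ccc(F)cc3)nc2c1` is 4-fluorophenyl in place of 3,4-dichlorophenyl on a saturated chain carbon bound to a nitrogen on an aromatic ring. Among the measured compounds shown here, no measured step touches this change, so the expected step is small, probably none beyond the scatter, perhaps a slightly higher number. Compound 4 is estimated at 60000 nM in this assay, range 25000 nM to 150000 nM, which means an expected step of a 1.2-fold higher number from compound 1 to compound 4 (0.08 log units; within the scatter).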

Compound 4, concentration lethal to 50% of the cells: < 100000 nM
Compound 4: a limit, no number (the forecaster's own chance of this, stated with the estimate: 30%); the middle value lies beyond the limit too.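

Compound 4 gives < 100000 nM in this assay, which is a limit and not a number, so no step from compound 1 can be read: the limit of < 100000 nM in this assay, at which 2 of the 4 values shown sit.

The compounds shown leave open whether 4-fluorophenyl in place of 3,4-dichlorophenyl changes the reading at all.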